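The source may report more compounds than this note shows. Statements on the series, on what has been measured and on what is new or still open speak of the compounds shown alone.

Measured compounds:
compound 1 `CC/C(=C(/c1ccc(/C=C/C(=O)O)cc1)c1ccc2[nH]cnc2c1)c1ccccc1` — 1180 nM
compound 2 `CC/C(=C(/c1ccc(/C=C/C(=O)O)cc1)c1ccc2[nH]ncc2c1)c1ccccc1Cl` — 2 nM

Among the measured compounds shown here, in a functional assay on MCF7 cells (Homo sapiens) for cytotoxicity, read by CellTiter-Glo, with a stated time of 5 days (a higher number here means a weaker inhibitor, a lower number a stronger inhibitor), compound 2 holds the lowest number of the two, and the nearest value, that of compound 1, is far higher, a gap well beyond the scatter; the two compounds differ in more than one place, so the data give no single step between them. Compound 3 `CC/C(=C(/c1ccc(/C=C/C(=O)O)cc1)c1ccc2[nH]ncc2c1)c1ccc(C#N)cc1C` has not yet been measured. It is derived from compound 2 by one change: 4-cyano-2-methylphenyl in place of 2-chlorophenyl on a double-bonded chain carbon bound to a double-bonded chain carbon and a saturated chain carbon. For the measured compounds named here, no measured step of this kind is available, so the direction rests on compound 2 alone, which in this assay gives 2 nM. Compound 3 is expected to lie close to compound 2, with the step of a 2.0-fold higher number from compound 2 to compound 3 (0.30 log units; within the scatter) estimated to be small and toward a slightly higher number. The estimate for compound 3 in this assay is 4 nM, with a range from 1 nM to 20 nM.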

Compound 3, half-maximal inhibitory concentration: 5 nM
For compound 3 the middle estimate is 1.3-fold (0.10 log units) below the measured one; the measured number falls inside the stated range.
By their numbers in this assay, from the lowest: compound 2; then compound 3; then compound 1.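

Among the compounds shown here, replacing 2-chlorophenyl with 4-cyano-2-methylphenyl on a double-bonded chain carbon bound to a double-bonded chain carbon and a saturated chain carbon gives the first reading of a single change at this position: in this assay it is a 2.5-fold higher number from compound 2 to compound 3 (0.40 log units; beyond the scatter), a modest loss. The number stays low without the chlorine, with compound 3 at 5 nM, so in this pair a low number does not depend on that atom and the position accepts a larger aromatic group that carries a nitrile. No measurement in hand explains the size of this step.

This single swap removes the chlorine and adds both the methyl and the nitrile, so their separate contributions cannot be told apart. As far as these compounds go, whether a methoxy group or an amine on this ring would keep the number equally low remains open.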